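Sulfate placement and fibroblast growth factor 2 affinity

The compounds below may be only part of what the source reports. "The series", "measured", "known", "first", "only" and "open" are said of these compounds alone.

The series holds four sulfated oligosaccharide conjugates built on a shared core carrying a cyclic disulfide linker. Compound 1 `CC(=O)N[C@H]1[C@@H](OC[C@@H](O)[C@@H](O)[C@H](O)[C@@H](O)CNc2cccc(NC(=O)CCCCC3CCSS3)c2)O[C@H](COS(=O)(=O)O)[C@H](O)[C@@H]1O[C@@H]1O[C@H](C(=O)O)[C@@H](O)[C@H](O)[C@H]1O` gives 36 nM in an assay on isolated protein for binding affinity to fibroblast growth factor 2 (Homo sapiens), read by surface plasmon resonance; a lower number here means tighter binding, a higher number weaker binding. Compound 2 `CC(=O)N[C@H]1[C@@H](OC[C@@H](O)[C@@H](O)[C@H](O)[C@@H](O)CNc2cccc(NC(=O)CCCCC3CCSS3)c2)O[C@H](CO)[C@H](O)[C@@H]1O[C@@H]1O[C@H](C(=O)O)[C@@H](O)[C@H](OS(=O)(=O)O)[C@H]1O` gives 25 nM in this assay; the two values lie within the scatter of each other. The cores of compound 1 and compound 2 share the same atoms joined differently; the difference between the two cores is not broken down here.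

Compound 3 `CC(=O)N[C@H]1[C@@H](OC[C@@H](O)[C@@H](O)[C@H](O)[C@@H](O)CNc2cccc(NC(=O)CCCCC3CCSS3)c2)O[C@H](COS(=O)(=O)O)[C@H](OS(=O)(=O)O)[C@@H]1O[C@@H]1O[C@H](C(=O)O)[C@@H](O)[C@H](O)[C@H]1O` gives 16 nM in this assay. It arises from compound 1 by sulfo in place of hydrogen on an oxygen on a saturated carbon, and this gave a 2.3-fold lower number from compound 1 to compound 3 (0.35 log units; beyond the scatter). Against compound 2, compound 3 stands within the scatter.

Compound 4 `CC(=O)N[C@H]1[C@@H](OC[C@@H](O)[C@@H](O)[C@H](O)[C@@H](O)CNc2cccc(NC(=O)CCCCC3CCSS3)c2)O[C@H](CO)[C@H](OS(=O)(=O)O)[C@@H]1O[C@@H]1O[C@H](C(=O)O)[C@@H](O)[C@H](OS(=O)(=O)O)[C@H]1O` has not yet been measured in this assay. It arises from compound 2 by sulfo in place of hydrogen on an oxygen on a saturated carbon, the same change as that from compound 1 to compound 3, at a place described in the same words. The step is seen only once among the measured compounds, so its size on the core of compound 2 rests on a single precedent. Compound 4 is expected to give 12 nM in this assay, with a range from 5 nM to 30 nM. For the measured compounds named here, the step is estimated as a 2.1-fold lower number from compound 2 to compound 4 (0.32 log units; beyond the scatter), taken from the earlier step because a 2.3-fold lower number from compound 1 to compound 3 (0.35 log units; beyond the scatter) is the only guide to this change, while the core of compound 2 may answer differently.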

Compound 4, dissociation constant: 41 nM
Estimate against measurement, compound 4: 3.4-fold (0.53 log units) below; the measured number lies above the stated range.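

On the core of compound 2, sulfo in place of hydrogen on an oxygen on a saturated carbon gave a 1.6-fold higher number from compound 2 to compound 4 (0.21 log units; within the scatter) in this assay, and the tighter binding seen for this change on the core of compound 1 did not appear here. The result of this change in this assay depends on the core that carries it, and a step measured on one core cannot be taken over as a fixed increment on the other: the same change on two cores in this assay, a 2.3-fold lower number (0.35 log units; beyond the scatter) from compound 1 to compound 3 and a 1.6-fold higher number (0.21 log units; within the scatter) from compound 2 to compound 4, 3.7-fold (0.57 log units) apart, beyond the scatter of two such steps. This rests on a single pair of steps on two cores; it does not show why the cores answer differently, and it does not establish that the change weakens binding on the core of compound 2, as that step lies within the scatter.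

The compounds shown leave open how hydroxy to sulfooxy behaves on any further core within this series. Also open, as far as these compounds go, is whether a phosphate ester or a methyl ether in place of the sulfooxy group would depend on the core in the same way.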